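Replacing Morpholine on a Sulfonyl Sulfur

This account rests on a few compounds, and the source may have more. Where it says the series, first, only, none or still open, it means among the compounds named here.

Measured compounds:
compound 1 `CCOC(=O)[C@@H]1CCCN(S(=O)(=O)c2ccc(S(=O)(=O)N3CCOCC3)cc2)C1` — 23400 nM
compound 2 `CCOC(=O)[C@@H]1CCCN(S(=O)(=O)c2ccc(S(=N)(=O)N(CC)CC)cc2)C1` — 3600 nM
compound 3 `CCOC(=O)N1CCC[C@H](S(=O)(=O)c2ccc(S(=O)(=O)N(CC)CC)cc2)C1` — > 30000 nM

In a functional assay on BXPC-3 cells (Homo sapiens) for inhibition, read by MTT assay, with a stated time of 7 days (on this read-out lower numbers stand for stronger inhibition and higher numbers for weaker inhibition), compound 1 gives 23400 nM, the highest of the two numbers reported, while compound 2 gives 3600 nM. For compound 3 the reading > 30000 nM is a limit of the assay rather than a number (the limit of > 30000 nM in this assay, at which 1 of the 3 values shown sits).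

Compound 4 `CCOC(=O)[C@@H]1CCCN(S(=O)(=O)c2ccc(S(=O)(=O)N(C)Cc3ccccc3)cc2)C1` differs from compound 1 by benzyl(methyl)amino in place of morpholin-4-yl on a sulfonyl sulfur. Among the measured compounds shown here, the only measured step touching this part of the molecule is a 6.5-fold lower number from compound 1 to compound 2 (0.81 log units; beyond the scatter), which exchanged the whole group on the aromatic carbon, ring for open chain, so it bears only partly on the present change. A modest fall in number is therefore expected, a 2.3-fold lower number from compound 1 to compound 4 (0.37 log units; beyond the scatter). Compound 4 is estimated to give 10000 nM, with a range from 3000 nM to 30000 nM.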

Compound 4, half-maximal inhibitory concentration: > 30000 nM
Compound 4: no number, only a limit (the forecaster's own chance of this, stated with the estimate: 15%); middle value at least 3.0-fold (0.47 log units) away from the limit.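

In this assay compound 4 reads only as a limit of the assay, not as a number: the limit of > 30000 nM in this assay, at which 2 of the 4 values shown sit.

The step is an at least 1.2-fold higher number from compound 1 to compound 4 (0.10 log units; that floor lies within the scatter), so benzyl(methyl)amino on this sulfonyl sulfur shows none of the fall seen in a 6.5-fold lower number from compound 1 to compound 2 (0.81 log units; beyond the scatter), and losing the morpholin-4-yl ring for an open group does not by itself lower the number. Whether the number truly rises cannot be told from this floor.

On these data alone, how dimethylamino or piperidin-1-yl would read on the same sulfonyl sulfur remains open.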